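Compound 1 without its methoxy group

The source may hold more compounds than are shown below. What is called first, only, known or untested is meant among the compounds shown, and "the series" means these compounds.

Among the compounds with values here, compound 1 `COc1ccc(-c2nc3sc(-c4ccccc4)cn3n2)cc1` gives 28% in a functional assay on NCI-H23 cells (Homo sapiens) for inhibition, read by sulforhodamine B assay, with a stated time of 48 h, tested at 10 uM (on this read-out higher numbers stand for more inhibition of growth at the one concentration tested and lower numbers for less inhibition of growth), and ranks second of the three numbers so far. Compound 3 `COc1ccc(-c2nc3sc(-c4ccc(Cl)cc4)cn3n2)cc1` stands higher with 41.5% and compound 2 `C/C(=N/O)c1ccc(NC(=O)Cn2nc(-c3ccccc3)nc2N)cc1` stands lower with 3.98% on a different scaffold. Compound 4 `c1ccc(-c2nc3sc(-c4ccccc4)cn3n2)cc1` carries hydrogen in place of methoxy on an aromatic carbon, a change counted as hydrogen in place of methoxy on an aromatic carbon and not yet measured. Within the data shown here, the only measured step on this core is a number 13.5 percentage points higher from compound 1 to compound 3 (beyond the scatter) for chloro in place of hydrogen on an aromatic carbon, elsewhere on the molecule. Among the measured compounds shown here, no measured step touches the methoxy group, so no shift beyond the scatter is expected, only an estimated a number 4 percentage points lower from compound 1 to compound 4 (within the scatter) in this assay at most plausibly. Compound 4 is estimated at 24% with a range from 10% to 40% for now.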

Compound 4, percent growth inhibition at one concentration: 16%
For compound 4 the middle estimate is 8 percentage points above the measured one, within the range that was stated.
By their numbers in this assay, from the lowest: compound 2; then compound 4; then compound 1; then compound 3.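

In this assay, within the data shown here, the methoxy group proves to matter at this position, on an aromatic carbon para to a large group: hydrogen in its place gives a number 12 percentage points lower from compound 1 to compound 4 (beyond the scatter), the first measured step here. Losing this one oxygen-bearing group thus moves the number beyond the scatter, which the earlier compounds could not show. No measurement at hand accounts for the shift. Open, as far as these compounds go, is whether an amine, a hydroxyl group or a longer ether chain at this carbon would lie with compound 1 or compound 4. Also open, from the compounds shown here alone, is whether the same change would carry over to the chloro-bearing compound 3.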